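The compounds below may be only part of what the source reports. "The series", "measured", "known", "first", "only" and "open" are said of these compounds alone.

Compound 1 `COc1cc2cc(Oc3ccc(NC(=O)Nc4ccccc4)cc3)c(C)nc2cc1OC` gives 48.9% in a functional assay on HT-29 cells (Homo sapiens) for inhibition, read by sulforhodamine B assay, with a stated time of 48 h, tested at 10 uM; a lower number here means a stronger effect, a higher number a weaker effect of the compound at the concentration tested.
Compound 2 `COc1cc2cc(Oc3ccc(NC(=O)Nc4ccc(C(F)(F)F)cc4)cc3)c(C)nc2cc1OC` gives 44.6% in this assay.

Within the data shown here, compound 1 stands highest of the two numbers in this assay, but the single measured step, a number 4.3 percentage points lower from compound 1 to compound 2 (within the scatter), lies within the scatter. Compound 3 `COc1cc2cc(Oc3ccc(NC(=O)Nc4ccc(Cl)c(Cl)c4)cc3)c(C)nc2cc1OC` departs from compound 1 by one change: 3,4-dichlorophenyl in place of phenyl on an amide-type nitrogen. That measured step bears on it, since it too changed the same phenyl by a substituent, and it moved little. A similar outcome, or a slight drift downward, is expected here, and the expected step of a number 6.9 percentage points lower from compound 1 to compound 3 (within the scatter) therefore stays modest. Compound 3 is estimated at 42% in this assay, with a range from 25% to 58%.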

Compound 3, a percentage reported as activity, at one concentration (the size of the read-out at that concentration, not a potency): 10.9%
Estimate against measurement, compound 3: 31.1 percentage points above, outside the stated range (below it).
By their numbers in this assay, from the lowest: compound 3; then compounds 2 and 1 (each within the scatter of the next).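

On the amide-type nitrogen, the choice of aryl group clearly matters in this assay: the change to 3,4-dichlorophenyl gives a number 38 percentage points lower from compound 1 to compound 3 (beyond the scatter) and, set against 4-(trifluoromethyl)phenyl, gives a number 33.7 percentage points lower from compound 2 to compound 3 (beyond the scatter) as well. Substitution on this phenyl is therefore not silent, as the earlier step alone had suggested, though the effect depends on the substituent. The compounds shown leave open whether a single chlorine on this phenyl would suffice or both are needed, and how a methoxy group or an amine there would read. Nothing given here accounts for the size of these steps.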